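The source may report more compounds than this note shows. Statements on the series, on what has been measured and on what is new or still open speak of the compounds shown alone.

Compound 1 `Nc1nc(NCc2ccccc2)nc(-c2ccccc2CO)n1` is the starting point. Going by the values given here, in a functional assay on cells for positive allosteric modulation of G-protein coupled receptor 68 (Homo sapiens), read by a luciferase reporter and cAMP accumulation, with a stated time of 30 min, at pH 6.8 and pH 8.3, in the presence of a further agent that is not named here (a higher number here means a more potent compound, by a factor of ten per unit of this negative logarithm, a lower number a less potent compound), compound 1 gives 4.35, the lowest of the three numbers known so far. Compound 2 `CCOc1ccc(-c2nc(N)nc(NCc3ccccc3)n2)c(CO)c1` gives 4.37, and the change a number 0.02 log units higher from compound 1 to compound 2 (within the scatter) shows that this ethoxy group left the number essentially unchanged. Compound 3 `Nc1nc(NCc2cccc(C(F)(F)F)c2)nc(-c2ccccc2CO)n1` gives 5.11, and the change a number 0.76 log units higher from compound 1 to compound 3 (beyond the scatter) is the only clear gain among the measured steps.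

Compound 4 `CCOc1ccc(CNc2nc(N)nc(-c3ccccc3CO)n2)cc1` differs from compound 1 in one place: ethoxy in place of hydrogen on an aromatic carbon. Among the compounds with values here, two measured steps bear on this. The step from compound 1 to compound 2 involves the same ethoxy group, but on the other aromatic ring, and it changed nothing beyond the scatter. The step from compound 1 to compound 3 puts a group on the same ring as in compound 4, though a different one, and it gave a modest rise. A small rise in this assay is therefore expected for compound 4, estimated as a number 0.25 log units higher from compound 1 to compound 4 (within the scatter), most likely close to the scatter. Compound 4 is expected to give 4.6, in the range from 4.2 to 5.1.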

Compound 4, negative logarithm of the antagonist equilibrium constant: 4.77
Compound 4: middle estimate off by 0.17 log units, on the low side, and the stated range covers the measured number.
By their numbers in this assay, from the lowest: compounds 1 and 2 (each within the scatter of the next); then compound 4; then compound 3.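

Placed para to a large group, the ethoxy group gives a number 0.42 log units higher from compound 1 to compound 4 (beyond the scatter) in this assay, whereas on the other aromatic ring the same group gave only a number 0.02 log units higher from compound 1 to compound 2 (within the scatter). The outcome of this change therefore depends on which ring carries the ethoxy group, and this ring has now given two rises, the other being a number 0.76 log units higher from compound 1 to compound 3 (beyond the scatter) with trifluoromethyl. Nothing available explains why ethoxy raises the number on this ring.

As far as these compounds go, it remains open what a methoxy group, a longer chain such as butoxy, or an amine would do at this same place. From the compounds shown here alone, it is also open whether ethoxy and trifluoromethyl together on this ring would raise the number further than either group alone.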